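From compound 2 to compound 3: a side-chain swap

A few compounds are considered here, and "the series" means these few. Any claim that something is new, unique, unknown or untested is made for them only; others in the source may bear on it.

Among the compounds with values here, in a functional assay on KETR3 cells (Homo sapiens) for inhibition, read by MTT assay, with a stated time of 120 h (a lower number here means a stronger inhibitor, a higher number a weaker inhibitor), compound 2 `CNC(=O)c1cccc(-c2ccc(NC(=O)Nc3ccc(Cl)c(C(F)(F)F)c3)cc2)c1` gives 39300 nM, the only number so far. Compound 1 `CNC(=O)/C(C)=C/c1ccc(NC(=O)Nc2ccc(Cl)c(C(F)(F)F)c2)cc1` reads > 50000 nM, which is a limit of the assay. Compound 3 `O=C(CCc1ccc(NC(=O)Nc2ccc(Cl)c(C(F)(F)F)c2)cc1)NC1CCC1` carries 2-(cyclobutylcarbamoyl)ethyl in place of 3-(methylcarbamoyl)phenyl on an aromatic carbon, para to a large group: 2-(cyclobutylcarbamoyl)ethyl in place of 3-(methylcarbamoyl)phenyl on an aromatic carbon. Within the data shown here, the only measured step bearing on this is an at least 1.2-fold lower number from compound 1 to compound 2 (0.10 log units; that floor lies within the scatter), whose floor lies within the scatter. No change beyond the scatter is expected, and the estimated step is a 1.0-fold higher number from compound 2 to compound 3 (0.01 log units; within the scatter). For compound 3 the expected value is 40000 nM, with an estimated range of 15000 nM to 70000 nM.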

Compound 3, half-maximal inhibitory concentration: > 50000 nM
Compound 3 ended at the assay's limit; the forecaster's own chance of this, stated with the estimate: 45%; middle value at least 1.2-fold (0.09 log units) away from the limit.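

At this position, on an aromatic carbon para to a large group, 2-(cyclobutylcarbamoyl)ethyl in place of 3-(methylcarbamoyl)phenyl gives an at least 1.2-fold higher number from compound 2 to compound 3 (0.10 log units; that floor lies within the scatter) in this assay, so losing the aromatic ring from the side chain and adding the cyclobutyl ring produce no step beyond the scatter. The step from compound 1 to compound 3 cannot be read, as both values are limits. Most of the series now sits at the edge of the readable range: the limit of > 50000 nM in this assay, at which 2 of the 3 values shown sit.

Still open, on these data alone, is whether an amine or a carboxylic acid at this position would give a value clearly inside that range.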